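A few compounds are considered here, and "the series" means these few. Any claim that something is new, unique, unknown or untested is made for them only; others in the source may bear on it.

Measured compounds in an ADME assay on cells (Homo sapiens) for cytotoxicity, read by polymerase chain reaction, with a stated time of 3 days; on this read-out lower numbers stand for higher toxicity in this test and higher numbers for lower toxicity in this test:
compound 1 `Nc1nc(Cl)c(-c2nccs2)c(N[C@@H]2C[C@H](CO)[C@@H](O)[C@H]2O)n1` — > 25000 nM
compound 2 `Nc1nc(Cl)c(-c2cc3ccccc3s2)c(N[C@@H]2C[C@H](CO)[C@@H](O)[C@H]2O)n1` — > 25000 nM
compound 3 `Cc1nc(NCC(C)C)nc(N[C@@H]2C[C@H](CO)[C@@H](O)[C@H]2O)c1-c1nc2ccccc2s1` — 10000 nM

Compound 1 gives > 25000 nM in this assay, which is a limit of the assay and not a number. Compound 2 likewise gives > 25000 nM, again a limit. Going by the values given here, compound 3 gives 10000 nM, the only actual number among the three values and therefore the only fixed point for comparison. The step that the two limits leave unreadable from compound 1 to compound 2 cannot be read, as the limit of > 25000 nM in this assay, at which 2 of the 3 values shown sit, shows that both of its ends sit at the same limit.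

Compound 4 `Cc1nc(NCc2ccsc2)nc(N[C@@H]2C[C@H](CO)[C@@H](O)[C@H]2O)c1-c1nc2ccccc2s1` differs from compound 3 by thiophen-3-yl in place of isopropyl on a saturated chain carbon bound to a nitrogen on an aromatic ring. Among the compounds with values here, no measured step concerns this kind of change: the one step recorded compares two other groups elsewhere on the shared core and is itself unreadable. With nothing to point either way, compound 4 is expected to sit close to compound 3, a step of no change at the digits printed from compound 3 to compound 4 (within the scatter) in this assay being the expectation, within the usual scatter. Compound 4 is therefore estimated at 10000 nM, with a range from 4000 nM to 25000 nM.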

Compound 4, half-maximal cytotoxic concentration: 6000 nM
Estimate against measurement, compound 4: 1.7-fold (0.22 log units) above; low and high end bracket the measured number.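

In this assay, going by these compounds alone, putting thiophen-3-yl in place of isopropyl on a saturated chain carbon bound to a nitrogen on an aromatic ring gives a 1.7-fold lower number from compound 3 to compound 4 (0.22 log units; within the scatter), the first step in this set that can be read. At this position, then, an aromatic ring containing sulfur can replace the isopropyl end of the chain with no change beyond the scatter, and both compounds give an actual number rather than a limit. The only earlier step cannot be read, since compound 1 and compound 2 both sit at a limit: the limit of > 25000 nM in this assay, at which 2 of the 4 values shown sit.

Going by these compounds, it remains open how an amine, a carboxylic acid or a longer alkyl chain at this place would read in this assay. Also open, on these data alone, is whether the same exchange would read alike on the core of compound 1.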